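The source may hold more compounds than are shown below. What is called first, only, known or untested is meant among the compounds shown, and "the series" means these compounds.

Working notes on the series. In a functional assay on SK-BR-3 cells (Homo sapiens) for cytotoxicity, read by sulforhodamine B assay, with a stated time of 3 days (on this read-out lower numbers stand for an effect already at smaller amounts and higher numbers for an effect only at larger amounts of compound), compound 2 (`COC(=O)c1c(C)coc1-c1ccc2c(c1OC)CCCC2(C)C`) gives 27.1 uM. Compound 1 (`Cc1coc(-c2ccc3c(c2O)CCCC3)c1C(=O)O`) gives 32.4 uM, within the scatter of compound 2, so these two together form the high end of the three numbers. Compound 3 (`Cc1coc(-c2ccc3c(c2O)CCCC3(C)C)c1C(=O)O`) gives 0.7 uM, a lower number than compound 2 and beyond the scatter.

The next compound to be read is compound 4 (`COCc1c(C)coc1-c1ccc2c(c1OC)CCCC2(C)C`). It has methoxymethyl in place of methoxycarbonyl on an aromatic carbon of the five-membered aromatic ring with 1 oxygen, and the rest of compound 2 is unchanged: methoxymethyl in place of methoxycarbonyl on an aromatic carbon.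

Among the measured compounds shown here, no measured pair isolates this change, so the data give no direct size for it. For the measured compounds named here, the only anchor is compound 2 at 27.1 uM, the one measured structure that differs from compound 4 in a single place. The low number of compound 3 at 0.7 uM gives no basis for expecting a comparable drop here. In this assay, no step beyond the scatter is expected, and the estimated step is a 1.1-fold higher number from compound 2 to compound 4 (0.04 log units; within the scatter). For compound 4 the estimated value is 30 uM, with an expected range from 12 uM to 75 uM.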

Compound 4, concentration for half-maximal effect: 18.5 uM
For compound 4 the middle estimate is 1.6-fold (0.21 log units) above the measured one; low and high end bracket the measured number.
By their numbers in this assay, from the lowest: compound 3; then compounds 4, 2 and 1 (each within the scatter of the next).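

In this assay, among the compounds shown here, methoxymethyl in place of methoxycarbonyl on this aromatic carbon of the five-membered ring gives a 1.5-fold lower number from compound 2 to compound 4 (0.17 log units; within the scatter), the first pair to isolate a change at this position, and the step cannot be told from the usual scatter. The entering group has no carbonyl and fewer hydrogen-bond acceptors than the group that leaves, yet with the rest of compound 2 unchanged, these differences produce no readable shift, so at this position in this setting, the number does not depend on the methoxycarbonyl group. Nothing on hand offers a measured explanation for this flat step.

The compounds shown leave open whether the position stays this flat for groups of a different kind, such as an aminomethyl group, a primary amide or an ether chain longer than methoxymethyl. For the compounds shown here, they also leave open whether the same exchange would read the same way on the core of compound 3, whose number lies far lower, since only one such pair is available and it sits at the high end of the series.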